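From 3-Methoxyphenyl to 3,4,5-Trimethoxyphenyl in a Growth Inhibition Series

The compounds below may be only part of what the source reports. "The series", "measured", "known", "first", "only" and "open" are said of these compounds alone.

Three related compounds have been tested in a functional assay on HCT-116 cells (Homo sapiens) for inhibition, read by sulforhodamine B assay, with a stated time of 48 h, tested at 50 uM; a higher number here means more inhibition of growth at the concentration tested, a lower number less inhibition of growth. Compound 1 (`COc1cccc(/C=C/C(=O)/C=C/c2ccc(OCc3cn(CCCCCOc4cc(=O)oc5ccccc45)nn3)c(OC)c2)c1`) gives 36%, and compound 2 (`COc1ccccc1/C=C/C(=O)/C=C/c1ccc(OCc2cn(CCCOc3cc(=O)oc4ccccc34)nn2)c(OC)c1`) gives 53%. Compound 3 (`COc1cccc(/C=C/C(=O)/C=C/c2ccc(OCc3cn(CCCCOc4cc(=O)oc5ccccc45)nn3)c(OC)c2)c1`) gives 44%, a number within the scatter of each of the other two, so nothing separates it from either. Among the measured compounds shown here, these three compounds differ from one another in more than one place, so no measured pair isolates a single structural change.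

The next compound, compound 4 (`COc1cc(/C=C/C(=O)/C=C/c2cc(OC)c(OC)c(OC)c2)ccc1OCc1cn(CCCCOc2cc(=O)oc3ccccc23)nn1`), has not yet been measured. It differs from compound 3 at one place, with 3,4,5-trimethoxyphenyl in place of 3-methoxyphenyl on a double-bonded chain carbon bound to a double-bonded chain carbon. For the measured compounds named here, the tested compounds say nothing directly about this exchange, so the expectation starts from compound 3 at 44%, the one tested compound a single change away.

In this assay, no step beyond the scatter is expected, and no firm direction can be assigned to it. The estimated change is a number 2 percentage points higher from compound 3 to compound 4 (within the scatter). Compound 4 is estimated at 46%, with an expected range from 30% to 62%.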

Compound 4, percent growth inhibition at one concentration: 63%
For compound 4 the middle estimate is 17 percentage points below the measured one; measured number outside the range, above it.
By their numbers in this assay, from the lowest: compounds 1, 3, 2 and 4 (each within the scatter of the next, the first and the last beyond it).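

In this assay, replacing 3-methoxyphenyl with 3,4,5-trimethoxyphenyl on a double-bonded chain carbon bound to a double-bonded chain carbon gives a number 19 percentage points higher from compound 3 to compound 4 (beyond the scatter), the first single-place step available in this series. Among the compounds shown here, it shows that the group at this place can alter growth inhibition at the concentration tested by more than the usual scatter, which the earlier compounds, differing in more than one place, could not show. The entering group has 12 heavy atoms and 3 hydrogen-bond acceptors against 8 and 1 for the group it replaces, but nothing at hand links either count to the higher number or otherwise explains the step.

With only this one exchange, the compounds shown do not reveal whether all three methoxy groups are needed, or whether 3,4-dimethoxyphenyl or an aryl group bearing a dimethylamino or carboxylic acid substituent would behave the same way. They also leave open whether the same exchange would give a similar step on the different linking chains of compound 1 and compound 2.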